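Moving the chloro group from compound 3 to compound 4

The compounds below may be only part of what the source reports. "The series", "measured", "known", "first", "only" and "open" are said of these compounds alone.

In a functional assay on HL-60 cells (Homo sapiens) for inhibition, read by MTT assay, with a stated time of 48 h, tested at 10 uM (on this read-out lower numbers stand for less inhibition of growth and higher numbers for more inhibition of growth at the one concentration tested), compound 3 `CN1CC[C@H](c2c(O)cc(O)c3c(=O)cc(/C=C/c4ccc(Cl)cc4)oc23)[C@H](O)C1` gives 58%, the second highest of three numbers. Compound 2 `CN1CC[C@H](c2c(O)cc(O)c3c(=O)cc(/C=C/c4ccccc4)oc23)[C@H](O)C1` gives 91%, and compound 1 `CCCCCCCCCC/C=C/c1c(C)oc2c([C@H]3CCN(C)C[C@H]3O)c(O)cc(O)c2c1=O` gives 9%. Compound 4 `CN1CC[C@H](c2c(O)cc(O)c3c(=O)cc(/C=C/c4cccc(Cl)c4)oc23)[C@H](O)C1` has the same atoms as compound 3, joined differently: 3-chlorophenyl in place of 4-chlorophenyl on a double-bonded chain carbon bound to a double-bonded chain carbon. The swap sits on a double-bonded chain carbon bound to a double-bonded chain carbon. Within the data shown here, the one measured step that bears on it is a number 33 percentage points lower from compound 2 to compound 3 (beyond the scatter), a large step that adds the chloro rather than moving it. No measurement shows what moving it does, so no step beyond the scatter is expected, though with real uncertainty. The expected step is a number 2 percentage points higher from compound 3 to compound 4 (within the scatter). For compound 4 the estimate is 60%, with an expected range from 35% to 85%.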

Compound 4, percent growth inhibition at one concentration: 35%
The estimate for compound 4 lay 25 percentage points above the measured number, within the range that was stated.
By their numbers in this assay, from the lowest: compound 1; then compound 4; then compound 3; then compound 2.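

Where the chloro sits on the ring matters, not only whether it is there: with the same atoms, going from 4-chlorophenyl to 3-chlorophenyl gives a number 23 percentage points lower from compound 3 to compound 4 (beyond the scatter) in this assay. Adding chloro in the 3-chlorophenyl form costs more than in the 4-chlorophenyl form, with a number 56 percentage points lower from compound 2 to compound 4 (beyond the scatter) on this read-out. Nothing available here explains the difference between the two placements.

On these data alone, whether methoxy or an amine on the phenyl ring would follow the same order between these two places remains open. So does whether any group on that ring can match the unsubstituted compound 2.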